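Pyridinyl for chlorophenyl on a cyclohexyl amide core

The source may hold more compounds than are shown below. What is called first, only, known or untested is meant among the compounds shown, and "the series" means these compounds.

Of the compounds shown here, three have been measured in an assay on HEK293 cells for displacement of a labelled ligand from metabotropic glutamate receptor 5 (Homo sapiens), with a stated time of 2 h; on this read-out lower numbers stand for stronger inhibition and higher numbers for weaker inhibition. Compound 1, `CN1CCc2nc(C#Cc3cccc(Cl)c3)ccc2C1=O`, gives 250 nM in this assay. Compound 2, `CN1CCc2nc(C#Cc3ccccn3)ccc2C1=O`, differs from compound 1 by pyridin-2-yl in place of 3-chlorophenyl on a triple-bonded carbon; in this assay compound 2 gives 6240 nM, and the step is a 25-fold higher number from compound 1 to compound 2 (1.40 log units; beyond the scatter). Compound 3, `O=C1c2ccc(C#Cc3cccc(Cl)c3)nc2CCN1C1CCCCC1`, differs from compound 1 by cyclohexyl in place of methyl on an amide-type nitrogen in a ring; in this assay compound 3 gives 12000 nM, with the step of a 48-fold higher number from compound 1 to compound 3 (1.68 log units; beyond the scatter). The values of compound 2 and compound 3 lie within the scatter of each other, so no order between them is claimed.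

Compound 4, `O=C1c2ccc(C#Cc3ccccn3)nc2CCN1C1CCCCC1`, has not been measured. It differs from compound 3 by pyridin-2-yl in place of 3-chlorophenyl on a triple-bonded carbon, and the place of the change is the same as in the pair of compound 1 and compound 2, so it is the same change, seen here for the second time. For the measured compounds named here, the only precedent for this change is the step from compound 1 to compound 2, which was large and beyond the scatter. Compound 4 is therefore expected to give a higher number than compound 3, with an expected step of a 13-fold higher number from compound 3 to compound 4 (1.10 log units; beyond the scatter), resting on the step of a 25-fold higher number from compound 1 to compound 2 (1.40 log units; beyond the scatter). Whether the two changes add up fully on the core of compound 3 is not known from these compounds. The estimate for compound 4 in this assay is 150000 nM, between 30000 nM and 600000 nM, and it is likely that only a limit would be reported.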

Compound 4, inhibition constant: 2240 nM
Compound 4: middle estimate off by 67-fold (1.83 log units), on the high side; the whole stated range lies above it.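

In this assay, pyridin-2-yl in place of 3-chlorophenyl on a triple-bonded carbon did not carry over from the core of compound 1 to the core of compound 3: here it gives a 5.4-fold lower number from compound 3 to compound 4 (0.73 log units; beyond the scatter), opposite in direction to the earlier step, and the two steps clearly differ: the same change on two cores in this assay, a 25-fold higher number (1.40 log units; beyond the scatter) from compound 1 to compound 2 and a 5.4-fold lower number (0.73 log units; beyond the scatter) from compound 3 to compound 4, 130-fold (2.13 log units) apart, beyond the scatter of two such steps

Cyclohexyl in place of methyl on the amide-type nitrogen behaves in the same way, now giving a 2.8-fold lower number from compound 2 to compound 4 (0.44 log units; beyond the scatter), again against the direction of the earlier step: the same change on two cores in this assay, a 48-fold higher number (1.68 log units; beyond the scatter) from compound 1 to compound 3 and a 2.8-fold lower number (0.44 log units; beyond the scatter) from compound 2 to compound 4, 130-fold (2.13 log units) apart, beyond the scatter of two such steps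

For the compounds shown here, in these four compounds, then, the effect of each change depends on the group present at the other place, so a step measured on one core could not be transferred to the other, but the data do not show why this happens, and with only two cores they give no rule for any further core.

As far as these compounds go, it remains open whether the reversal would appear with other groups on the amide-type nitrogen, such as ethyl, isopropyl or benzyl. From the compounds shown here alone, it is also open whether it extends to other groups on the triple-bonded carbon, such as pyridin-3-yl or 3-fluorophenyl.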